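The source may report more compounds than this note shows. Statements on the series, on what has been measured and on what is new or still open speak of the compounds shown alone.

Measured so far:
- Compound 1 `CCNC(=O)Nc1ccc(/C=C/c2cccc(Cl)c2)cc1`: > 20000 nM in a functional assay on HT-1080 cells (Homo sapiens) for inhibition, read by sulforhodamine B assay, with a stated time of 48 h (a lower number here means a stronger inhibitor, a higher number a weaker inhibitor), a limit of the assay and not a number
- Compound 2 `CCNC(=O)Nc1ccc(/C=C\c2cccc(Cl)c2)cc1`: 31000 nM in this assay, a measured number

Among the measured compounds shown here, compound 2 holds the only number so far, since the other result is a limit. The next case is compound 3 `O=C1NCCN1c1ccc(/C=C\c2cccc(Cl)c2)cc1`, and its difference from compound 2 is 2-oxoimidazolidin-1-yl in place of (ethylcarbamoyl)amino on an aromatic carbon with the new group on an aromatic carbon, para to a group of 9 heavy atoms.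

For the measured compounds named here, the one measured step is a step that the limit leaves unreadable from compound 1 to compound 2 and it concerns the fact that compounds 1 and 2 differ only in the configuration as drawn rather than the group that changes here. Going by the values given here, its size cannot be read, so no measured step gives a size or direction for this replacement. The expected step is a 1.2-fold lower number from compound 2 to compound 3 (0.09 log units; within the scatter) in this assay and no shift beyond the usual scatter is expected. That expectation rests on compound 2 at 31000 nM alone, so the range stays wide. The estimate for compound 3 is 25000 nM with an expected range from 8000 nM to 80000 nM in this assay and a report as a limit remains possible.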

Compound 3, half-maximal inhibitory concentration: 35 nM
Beside the measured number, compound 3's estimate is 710-fold (2.85 log units) above it; the whole stated range lies above it.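

Up to compound 2 the series gave no readable size, since compound 1 stands as a limit and not a number: the limit of > 20000 nM in this assay, at which 1 of the 3 values shown sits. At the aromatic carbon para to a group of 9 heavy atoms, 2-oxoimidazolidin-1-yl in place of (ethylcarbamoyl)amino gives an 890-fold lower number from compound 2 to compound 3 (2.95 log units; beyond the scatter) in this assay, so the result at this position depends strongly on which of these two groups it carries. The two groups match in 6 heavy atoms (3 carbon, 2 nitrogen, 1 oxygen) and in having no net charge, and they differ in the one five-membered non-aromatic ring and in 1 hydrogen-bond donor against 2, but nothing shown links either difference to the size of the step.

The compounds shown leave open whether the ring or the donor count carries the step, and how the double bond configuration reads with 2-oxoimidazolidin-1-yl in place. Also open, from the compounds shown here alone, is how a primary amine or a carboxylic acid on the same aromatic carbon would read in this assay.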